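A few compounds are considered here, and "the series" means these few. Any claim that something is new, unique, unknown or untested is made for them only; others in the source may bear on it.

Measured so far in an ADME assay on MT4 cells (Homo sapiens) for cytotoxicity, read by MTT assay, with a stated time of 4 days; on this read-out higher numbers stand for lower toxicity in this test and lower numbers for higher toxicity in this test:
- compound 1 `COc1ccc(-c2oc3ccc(NC(C)=O)cc3c(=O)c2O)cc1` gives 98700 nM
- compound 2 `Nc1ccc2oc(-c3ccccc3)c(O)c(=O)c2c1` gives 217000 nM
- compound 3 `COc1ccccc1-c1oc2ccc(N)cc2c(=O)c1O` gives 222000 nM

Compound 2 stands level with compound 3, the measured step being a 1.0-fold higher number from compound 2 to compound 3 (0.01 log units; within the scatter) and no more. Compound 1 sits lower than compound 2, beyond the scatter.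

Still unmeasured is compound 4 `COc1ccc(-c2oc3ccc(N)cc3c(=O)c2O)cc1` and its structure departs from compound 2 in a single place: methoxy in place of hydrogen on an aromatic carbon is the whole change. For the measured compounds named here, one measured step bears directly on it, the same kind of exchange, methoxy in place of hydrogen on an aromatic carbon. In compound 3 that methoxy stands at another place, and the step was a 1.0-fold higher number from compound 2 to compound 3 (0.01 log units; within the scatter) in this assay with nothing beyond the scatter. Compound 4 shares its methoxy with compound 1, which gives 98700 nM but differs elsewhere on the core, so that value only widens the lower side of the expectation.

No step beyond the scatter is therefore expected, and the estimated step is a 1.1-fold lower number from compound 2 to compound 4 (0.06 log units; within the scatter) in all likelihood. Compound 4 is expected at 190000 nM in this assay with an estimated range of 105000 nM to 340000 nM for repeated measurements.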

Compound 4, half-maximal cytotoxic concentration: 239000 nM
Estimate against measurement, compound 4: 1.3-fold (0.10 log units) below; measured number inside the range.
By their numbers in this assay, from the lowest: compound 1; then compounds 2, 3 and 4 (each within the scatter of the next).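

Read in this assay, methoxy in place of hydrogen, on an aromatic carbon para to a large group, gives a 1.1-fold higher number from compound 2 to compound 4 (0.04 log units; within the scatter) and so leaves the number level at this place, just as the same exchange did at the other place it takes in compound 3. The result also supplies the single-place comparison that compound 1 lacked: hydrogen in place of acetyl on the nitrogen gives a 2.4-fold higher number from compound 1 to compound 4 (0.38 log units; beyond the scatter) in this assay, a modest step toward lower toxicity in this test, so the lower number of compound 1 goes with the acetyl on that nitrogen and not with the methoxy it shares with compound 4. No measurement is available that would account for the size of either step.

Going by these compounds, whether this place would stay as level with a hydroxyl, an ethoxy chain or a carboxylic acid in place of the methoxy remains open. Also open, on these data alone, is whether the acetyl step holds without the methoxy, or with a methyl or a longer acyl chain on the nitrogen instead.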